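Tert-butoxy for tert-butyl on a prodrug ester carbonyl

This account rests on a few compounds, and the source may have more. Where it says the series, first, only, none or still open, it means among the compounds named here.

Compound 1 `C[C@@H](O)[C@H]1C(=O)N2C(C(=O)OCOC(=O)C(C)(C)C)=C(S[C@@H]3CN[C@H](C(=O)Nc4cccc(C(=O)O)c4)C3)[C@H](C)[C@H]12` was measured in an ADME assay on a cell-free system (plasma, Rattus norvegicus) for metabolic stability, read by LC-MS, with a stated time of 60 min, at 37 degrees C, tested at 50 uM (a lower number here means that less of the compound is left, a higher number that more of the compound is left), and gave 0%. Compound 2 `Cc1oc(=O)oc1COC(=O)N1C[C@@H]2C[C@H]1C(=O)Nc1cccc(c1)C(=O)OC/C=C\COC(=O)C1=C(S2)[C@H](C)[C@@H]2[C@@H]([C@@H](C)O)C(=O)N12` gave 0% in this assay, so compound 1 stands level with compound 2 within the scatter. Compound 3 `C[C@@H](O)[C@H]1C(=O)N2C(C(=O)OCOC(=O)OC(C)(C)C)=C(S[C@@H]3CN[C@H](C(=O)Nc4cccc(C(=O)O)c4)C3)[C@H](C)[C@H]12` is not yet measured; it differs from compound 1 by tert-butoxy in place of tert-butyl on a carbonyl carbon. Among the compounds with values here, with no step between measured compounds to lean on, the account expects no change beyond the scatter from compound 1 to compound 3, that is a step of no change at the digits printed from compound 1 to compound 3 (within the scatter). Compound 3 is therefore estimated at 0% in this assay, within 0% to 10%.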

Compound 3, percent of the compound remaining in the plasma assay: 0%
Compound 3: the middle estimate sits on the measured number at the digits printed; the range from low to high includes it.
By their numbers in the plasma assay, from the lowest: compounds 1, 2 and 3 (each within the scatter of the next).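

In the plasma assay, tert-butoxy in place of tert-butyl on a carbonyl carbon gives no change at the digits printed from compound 1 to compound 3 (within the scatter), so this change leaves the plasma read-out where it was. In a physicochemical assay for metabolic stability, read by LC-MS, in phosphate buffer, with a stated time of 3 h, at pH 7.4, tested at 50 uM (a lower number here means that less of the compound is left, a higher number that more of the compound is left), compound 1 gives > 95%, which is a limit of the assay. In the physicochemical assay, compound 3 gives > 95%, also a limit, and the step in that assay cannot be read: the limit of > 95% in the physicochemical assay, at which 2 of the 2 values shown sit.

From the compounds shown here alone, whether an amine or a longer chain on this carbonyl carbon would leave any compound remaining in the plasma assay stays open. Going by these compounds, how quickly compound 1 and compound 3 are lost there also stays open.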